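Adding a Methoxy to the Ring of Compound 1

The source may report more compounds than this note shows. Statements on the series, on what has been measured and on what is new or still open speak of the compounds shown alone.

Compound 1 `Oc1cc2cc(c1O)Oc1ccc(cc1)CCc1cccc(O)c1Oc1cccc(c1)CC2` is a ring-shaped molecule carrying several hydroxy groups on its aromatic rings. In a functional assay on RAW264.7 cells (Mus musculus) for inhibition, read by Griess assay, with stated times of 1 h and 24 h (a lower number here means a stronger inhibitor, a higher number a weaker inhibitor), compound 1 gives 1440 nM, the lowest number among the three compounds measured. Compound 2 `Oc1cc2cc(c1O)Oc1ccc(cc1)CCc1ccc(O)c(O)c1Oc1cccc(c1)CC2` carries one more hydroxy and gives 4100 nM; the step of a 2.8-fold higher number from compound 1 to compound 2 (0.45 log units; beyond the scatter). Compound 3 `Oc1ccc2cc1Oc1ccc(cc1)CCc1cccc(O)c1Oc1cccc(c1)CC2` lacks one of the hydroxy groups present in the other two, and compound 3 gives 13300 nM; the step of a 9.2-fold higher number from compound 1 to compound 3 (0.97 log units; beyond the scatter). Both measured steps weaken inhibition, and both concern a hydroxy on an aromatic carbon.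

Compound 4 `COC1Cc2cccc(c2)Oc2c(O)cccc2CCc2ccc(cc2)Oc2cc1cc(O)c2O` differs from compound 1 in one place: methoxy in place of hydrogen on a saturated ring carbon. Neither measured step involves a saturated ring carbon or a methoxy, so no measured change speaks directly to this one. The two known changes to compound 1 each raised the number, but the present change is of a different kind, so only a small step is expected, leaning toward a higher number. For compound 4 the expected step is a 1.5-fold higher number from compound 1 to compound 4 (0.18 log units; within the scatter). Compound 4 is therefore estimated to give 2200 nM, within 700 nM to 7000 nM.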

Compound 4, half-maximal inhibitory concentration: 62200 nM
For compound 4 the middle estimate is 28-fold (1.45 log units) below the measured one; measured number outside the range, above it.
By their numbers in this assay, from the lowest: compound 1; then compound 2; then compound 3; then compound 4.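

Going by these compounds alone, a saturated ring carbon, untouched by the earlier compounds, proves highly sensitive in this assay: methoxy in place of hydrogen there gives a 43-fold higher number from compound 1 to compound 4 (1.64 log units; beyond the scatter), a large step. Compound 4 keeps every hydroxy group of compound 1, so those groups alone do not secure inhibition here, and this change outweighs both steps at aromatic carbons, a 2.8-fold higher number from compound 1 to compound 2 (0.45 log units; beyond the scatter) and a 9.2-fold higher number from compound 1 to compound 3 (0.97 log units; beyond the scatter). No available evidence explains why this methoxy has so large an effect.

With methoxy as the only group shown on this carbon, it remains open whether the weakening belongs to methoxy or would follow any replacement of the hydrogen. A methyl, an amine or a longer chain such as ethoxy at the same place would separate these two readings.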